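Extending the Carboxy Chain Past Compound 3

The source may report more compounds than this note shows. Statements on the series, on what has been measured and on what is new or still open speak of the compounds shown alone.

In a functional assay on RT16 cells (Cricetulus griseus) for inhibition, read by CellTiter-Blue, with a stated time of 96 h (on this read-out higher numbers stand for weaker inhibition and lower numbers for stronger inhibition), compound 1 (`Nc1nc2[nH]c(CCCCCC(=O)O)cc2c(=O)[nH]1`) gives > 1000 nM, which is a limit. Compound 2 (`Nc1nc2[nH]c(CCCCCCC(=O)O)cc2c(=O)[nH]1`) gives > 1000 nM, also a limit. Compound 3 (`Nc1nc2[nH]c(CCCCCCCC(=O)O)cc2c(=O)[nH]1`) gives > 1000 nM, again a limit. For the measured compounds named here, the series so far offers only (the limit of > 1000 nM in this assay, at which 3 of the 3 values shown sit), so no number places compound 3 among its neighbours.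

Compound 4 (`Nc1nc2[nH]c(CCCCCCCCC(=O)O)cc2c(=O)[nH]1`) has carboxymethyl in place of carboxy on a saturated chain carbon, seven bonds along the chain from an aromatic carbon. Closest is a step that the two limits leave unreadable from compound 2 to compound 3, followed by a step that the two limits leave unreadable from compound 1 to compound 2 and a step that the two limits leave unreadable from compound 1 to compound 3. None of these has a readable size, so no step beyond the scatter is expected in this assay, in either direction. The expected outcome is a step that the limit leaves unreadable from compound 3 to compound 4. Compound 4 is estimated at 1500 nM, with an expected range of 600 nM to 5000 nM.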

Compound 4, half-maximal inhibitory concentration: > 10000 nM
Compound 4 gave a limit, no number (the forecaster's own chance of this, stated with the estimate: 85%); middle value at least 6.6-fold (0.82 log units) from the limit.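

Compound 4, like compounds 1, 2 and 3, gives only a limit in this assay, so no step among these four compounds can be read. The compounds shown leave open whether any of these chains gives a measurable inhibitory concentration.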